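Swapping a Chain Amine for a Ring Amine

The source may report more compounds than this note shows. Statements on the series, on what has been measured and on what is new or still open speak of the compounds shown alone.

Of the compounds shown here, two sharing one core have been tested in a functional assay on HepG2 cells (Homo sapiens) for antiproliferative activity, read by MTT assay, with a stated time of 48 h; on this read-out higher numbers stand for weaker inhibition and lower numbers for stronger inhibition. Compound 1, with the structure `O=c1cc(-c2ccccc2)oc2cc(OCc3ccccc3)c(OCCCN3CCCC3)c(O)c12`, gives 4200 nM in this assay. Compound 2, with the structure `CCN(CC)CCCOc1c(OC)cc2oc(-c3ccccc3)cc(=O)c2c1O`, gives 3700 nM in this assay. The two numbers lie within the scatter of each other, so compound 2 stands at one end of this pair without being separated from compound 1 in any meaningful way.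

Compound 3, with the structure `COc1cc2oc(-c3ccccc3)cc(=O)c2c(O)c1OCCCN1CCCCC1`, has not yet been measured. It differs from compound 2 in one place: piperidin-1-yl in place of diethylamino on a saturated chain carbon, three bonds along the chain from an oxygen on an aromatic ring. Among the measured compounds shown here, no step between two measured compounds shows how such a change plays out here, so there is nothing to point toward a gain or a loss. The expected step in this assay, no change at the digits printed from compound 2 to compound 3 (within the scatter), is therefore none beyond the scatter. On that basis compound 3 is expected to give about 3700 nM in this assay, with a likely range from 1800 nM to 7500 nM.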

Compound 3, half-maximal inhibitory concentration: 22300 nM
Compound 3: middle estimate off by 6.0-fold (0.78 log units), on the low side; measured number outside the range, above it.
By their numbers in this assay, from the lowest: compounds 2 and 1 (each within the scatter of the next); then compound 3.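

In this assay, exchanging 3-(diethylamino)propyl for 3-(piperidin-1-yl)propyl gives a 6.0-fold higher number from compound 2 to compound 3 (0.78 log units; beyond the scatter), so this amine cannot be swapped freely on this core: the ring amine goes with weaker inhibition here. The change looks small when written out, since the group grows only from five heavy atoms to six, gains one six-membered non-aromatic ring, and keeps the same counts of hydrogen-bond donors and acceptors, yet the read-out moves beyond the usual scatter. No measurement here explains why this happens, so the step records an outcome rather than a cause.

This single pair cannot separate the effect of closing a ring from that of adding a carbon, nor show whether the same step would appear on another core. It also leaves open where morpholin-4-yl or dimethylamino on the same propyl chain would fall relative to compound 2 and compound 3, and whether a longer chain carrying diethylamino or piperidin-1-yl would change the picture.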